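Changing the Aryl Group on the Ring Nitrogen

The source may report more compounds than this note shows. Statements on the series, on what has been measured and on what is new or still open speak of the compounds shown alone.

The measured compounds and their values:
Compound 1, `N#CC1=C(N)Oc2c(c3nc4ccccc4nc3c3ccccc23)C12C(=O)N(Cc1cnnn1-c1cccc(Br)c1)c1ccccc12`: in a functional assay on MCF7 cells (Homo sapiens) for antiproliferative activity, read by MTT assay, with a stated time of 48 h (a higher number here means a weaker inhibitor, a lower number a stronger inhibitor), compound 1 gives > 50000 nM, which is a limit of the assay and not a number.
Compound 2, `CC(=O)Nc1ccc(-n2nncc2CN2C(=O)C3(C(C#N)=C(N)Oc4c3c3nc5ccccc5nc3c3ccccc43)c3ccccc32)cc1`: in this assay compound 2 gives > 50000 nM, again a limit of the assay.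
Compound 3, `N#CC1=C(N)Oc2c(N)cc3nc4ccccc4nc3c2C12C(=O)N(Cc1cnnn1-c1ccc(Cl)cc1)c1ccccc12`: in this assay compound 3 gives > 50000 nM, also a limit of the assay.

Compound 3 therefore stands at the limit of > 50000 nM in this assay, at which 3 of the 3 values shown sit, and nothing finer than that limit is known for it. The unmeasured compound 4, `N#CC1=C(N)Oc2c(N)cc3nc4ccccc4nc3c2C12C(=O)N(Cc1cnnn1-c1ccc(F)c(Cl)c1)c1ccccc12`, differs from compound 3 in one place: 3-chloro-4-fluorophenyl in place of 4-chlorophenyl on an aromatic nitrogen.

For the measured compounds named here, the only measured step of a comparable kind is the change of the aryl group on an aromatic nitrogen going from compound 1 to compound 2, and that step is a step that the two limits leave unreadable from compound 1 to compound 2, so its size cannot be read. Going by the values given here, the change from compound 3 to compound 4 keeps the same ring and the same kind of substituent, and no measured step shows that such a change moves the value out of the limit. Compound 4 is therefore expected to remain at the limit, with an estimated step of a number no higher from compound 3 to compound 4 (the limit leaves the size open) in this assay. The estimate for compound 4 is 50000 nM, expected to lie between 20000 nM and 100000 nM.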

Compound 4, half-maximal inhibitory concentration: 17800 nM
The estimate for compound 4 lay 2.8-fold (0.45 log units) above the measured number, outside the stated range (below it).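

The aryl group on the aromatic nitrogen turns out to be a place where the value can leave the limit: in this assay, 3-chloro-4-fluorophenyl in place of 4-chlorophenyl gives an at least 2.8-fold lower number from compound 3 to compound 4 (0.44 log units; beyond the scatter). For the compounds shown here, the earlier step between compound 1 and compound 2 could not be read, so this is the first evidence that a change at this position can register at all, and it comes from a small change that keeps the same ring and adds a single heavy atom. Compound 4 is also the only compound shown with a number rather than a limit: the limit of > 50000 nM in this assay, at which 3 of the 4 values shown sit.

The compounds shown leave open whether the step follows the added fluorine, the different place of the chlorine, or the two together, which a 3-chlorophenyl or a 4-fluorophenyl group on the same core would separate. Going by these compounds, it also remains open whether a 3,4-dichlorophenyl group, or an amine or a carboxylic acid on this aryl ring, would lower the number further, and whether 3-chloro-4-fluorophenyl would bring the core of compound 1 off the limit.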